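A few compounds are considered here, and "the series" means these few. Any claim that something is new, unique, unknown or untested is made for them only; others in the source may bear on it.

Measured in an ADME assay on cells (Peritoneal macrophage, Mus musculus, strain Balb/c) for cytotoxicity, read by resazurin assay, with a stated time of 72 h; on this read-out lower numbers stand for higher toxicity in this test and higher numbers for lower toxicity in this test:
compound 1 `N/C(=N\O)c1ccc(C2=C(S(=O)(=O)c3ccc(F)cc3)CC3(CCCCC3)O2)cc1`; compound 1 gives 92900 nM
compound 2 `CC1(Cc2cccc(/C(N)=N/O)c2)CC(S(=O)(=O)c2ccc(F)cc2)=C(c2ccc(/C(N)=N/O)cc2)O1`; compound 2 gives 50200 nM
compound 3 `CC1(Cc2ccc([N+](=O)[O-])cc2)CC(S(=O)(=O)c2ccc(F)cc2)=C(c2ccc(/C(N)=N/O)cc2)O1`; compound 3 gives 97400 nM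

The three numbers all lie within the usual scatter of one another; compound 3 is nearest to compound 1 and furthest from compound 2. Among the measured compounds shown here, the only measured step that changes the group on the saturated chain carbon, a 1.9-fold higher number from compound 2 to compound 3 (0.29 log units; within the scatter), stays within the scatter as well.

Compound 4 `CC1(Cc2ccccc2Br)CC(S(=O)(=O)c2ccc(F)cc2)=C(c2ccc(/C(N)=N/O)cc2)O1` has not yet been measured. Its difference from compound 3 is as follows.
2-bromophenyl in place of 4-nitrophenyl on a saturated chain carbon bound to a saturated ring carbon
For the measured compounds named here, no measured pair carries a 2-bromophenyl group, so this step has no direct precedent. Going by the values given here, the one step at the same place, a 1.9-fold higher number from compound 2 to compound 3 (0.29 log units; within the scatter), gives no sign that swapping the aryl group on the saturated chain carbon moves this read-out beyond the scatter, and the same is expected here. Compound 4 is therefore expected to give about 85000 nM, with an estimated range from 40000 nM to 180000 nM. The expected step, a 1.1-fold lower number from compound 3 to compound 4 (0.06 log units; within the scatter), is one with no direction beyond the scatter.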

Compound 4, half-maximal cytotoxic concentration: 109000 nM
Compound 4: the middle estimate sits 1.3-fold (0.11 log units) below what was measured; measured number inside the range.
By their numbers in this assay, from the lowest: compounds 2, 1, 3 and 4 (each within the scatter of the next, the first and the last beyond it).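

In this assay, 2-bromophenyl in place of 4-nitrophenyl on a saturated chain carbon bound to a saturated ring carbon stays within the scatter (a 1.1-fold higher number from compound 3 to compound 4 (0.05 log units; within the scatter)), so a group with 0 hydrogen-bond acceptors and no nitrogen or oxygen leaves the read-out where the nitro-bearing group had it. The step from the amidoxime-bearing aryl group of compound 2 gives the first difference at this place beyond the scatter, though a modest one (a 2.2-fold higher number from compound 2 to compound 4 (0.34 log units; beyond the scatter)), and it points to lower toxicity in this test for compound 4. Nothing available explains these numbers.

The compounds shown leave open whether a carboxylic acid or an amine on this chain carbon, in place of the aryl ring, would keep the number in this range. Going by these compounds, a longer chain carrying the same 2-bromophenyl also remains open.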